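The compounds below may be only part of what the source reports. "The series", "measured", "known", "first", "only" and "open" are said of these compounds alone.

Compound 1 `CCn1c(C(=O)N[C@@H](C)C(=O)OC)ccc1C(CC)(CC)c1ccc(OCS(=O)(=O)c2ccccc2)c(C)c1`, compound 2 `CCn1c(C(=O)NCC(=O)OC)ccc1C(CC)(CC)c1ccc(OCS(=O)(=O)c2ccccc2)c(C)c1` and compound 3 `CCn1c(C(=O)N[C@H](CO)CCCO)ccc1C(CC)(CC)c1ccc(OCS(=O)(=O)c2ccccc2)c(C)c1` have been measured in a functional assay on PC-3 cells (Homo sapiens) for antiproliferative activity, read by MTT assay, with a stated time of 24 h; on this read-out higher numbers stand for weaker inhibition and lower numbers for stronger inhibition. Compound 1 gives only a limit there, > 50000 nM. Compound 2 likewise gives only a limit, > 50000 nM. Compound 3 gives a number, 6810 nM. Compound 1 therefore stands at the limit of > 50000 nM in this assay, at which 2 of the 3 values shown sit, without a number of its own.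

Compound 4 `CCn1c(C(=O)N[C@@H](CO)CCCO)ccc1C(CC)(CC)c1ccc(OCS(=O)(=O)c2ccccc2)c(C)c1` is not yet measured. For the measured compounds named here, it differs from compound 1 by a group of 7 heavy atoms (5 carbon, 2 oxygen; no ring) in place of a group of 6 heavy atoms (4 carbon, 2 oxygen; no ring), on an amide-type nitrogen; the group that enters is the one carried by compound 3, with its one defined stereocentre set the other way. Going by the values given here, the steps that bear on this change are an at least 7.3-fold lower number from compound 1 to compound 3 (0.86 log units; beyond the scatter) and an at least 7.3-fold lower number from compound 2 to compound 3 (0.86 log units; beyond the scatter), while a step that the two limits leave unreadable from compound 1 to compound 2. A lowering of similar size is expected, an at least 5.0-fold lower number from compound 1 to compound 4 (0.69 log units; beyond the scatter). Compound 4 is estimated at 10000 nM, in a range from 3000 nM to 40000 nM.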

Compound 4, half-maximal inhibitory concentration: 13400 nM
Estimate against measurement, compound 4: 1.3-fold (0.13 log units) below, and the stated range covers the measured number.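

In this assay the lowering seen with compound 3 does not depend on one drawn configuration, as the entering group set the other way still gives an at least 3.7-fold lower number from compound 1 to compound 4 (0.57 log units; beyond the scatter) and an at least 3.7-fold lower number from compound 2 to compound 4 (0.57 log units; beyond the scatter). Inverting its stereocentre gives a 2.0-fold higher number from compound 3 to compound 4 (0.29 log units; within the scatter), so the two forms cannot be told apart in this assay. That comparison isolates the stereocentre alone: the fact that compounds 3 and 4 differ only in the configuration as drawn

The compounds shown do not separate the loss of the methoxycarbonyl group from the change in chain. They also leave open whether an amine, a carboxylic acid or a longer chain on this amide-type nitrogen would give a similar lowering.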